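Back from a urea to a plain benzamide on the shared core

The compounds below may be only part of what the source reports. "The series", "measured", "known", "first", "only" and "open" are said of these compounds alone.

Compound 1, `COc1cc(-c2nn(-c3cccc(NC(=O)c4cccc(C(F)(F)F)c4)c3)cc2-c2ccncc2)ccc1Cl`: > 50000 nM
Compound 2, `COc1cc(-c2nn(-c3cccc(NC(=O)Nc4ccc(Cl)c(C(F)(F)F)c4)c3)cc2-c2ccncc2)ccc1Cl`: 21500 nM

In a functional assay on HT-29 cells (Homo sapiens) for inhibition, read by sulforhodamine B assay, with a stated time of 48 h (a higher number here means that more compound is tolerated, a lower number that less compound is tolerated), compound 1 gives only a limit, > 50000 nM. Among the measured compounds shown here, compound 2 is the single compound with a measured number here, and the other value shown is a limit. For the measured compounds named here, the one measured step is an at least 2.3-fold lower number from compound 1 to compound 2 (0.36 log units; beyond the scatter), which moves toward the numerical value when the urea-type substituent enters. Compound 3, `COc1cc(-c2nn(-c3cccc(NC(=O)c4ccccc4)c3)cc2-c2ccncc2)ccc1Cl`, reverses that direction and goes further: phenyl in place of (4-chloro-3-(trifluoromethyl)phenyl)amino on a carbonyl carbon. Because compound 1, which still carries a trifluoromethyl group on its benzamide, already sits at the limit (the limit of > 50000 nM in this assay, at which 1 of the 2 values shown sits), the stripped benzamide of compound 3 is expected to return to that region, in the direction opposite to the measured step. Compound 3 is therefore expected to give 60000 nM, with a range of 20000 nM to 200000 nM, most likely reported as a limit. The expected step is a 2.8-fold higher number from compound 2 to compound 3 (0.45 log units; beyond the scatter).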

Compound 3, concentration lethal to 50% of the cells: > 100000 nM
Compound 3: no number, only a limit; the forecaster's own chance of this, stated with the estimate: 70%; middle value at least 1.6-fold (0.22 log units) from the limit.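

In this assay compound 3 gives only a limit, > 100000 nM. Taking out the (4-chloro-3-(trifluoromethyl)phenyl)amino group and placing phenyl on the carbonyl carbon gives an at least 4.6-fold higher number from compound 2 to compound 3 (0.66 log units; beyond the scatter), so this change is now seen from the urea toward a benzamide carrying no ring substituent, and the number rises again. Among these three compounds, only the urea compound 2 has a measured number, while both benzamides stay at limits, and the step between compound 1 and compound 3 cannot be read.

Going by these compounds, what stays open is whether the amino linkage or the chloro and trifluoromethyl substituents account for the lower number of compound 2. A plain phenylamino group or a 4-chloro-3-(trifluoromethyl)phenyl group on the same carbonyl carbon would separate the two.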